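The source may hold more compounds than are shown below. What is called first, only, known or untested is meant among the compounds shown, and "the series" means these compounds.

- compound 1 `COc1cc(OC)c(/C=C/S(=O)(=O)Nc2ccc(OC)c([N+](=O)[O-])c2)c(OC)c1`: 2500 nM
- compound 2 `COC(=O)CNc1cc(NS(=O)(=O)/C=C/c2c(OC)cc(OC)cc2OC)ccc1OC`: 350 nM
- compound 3 `COC(=O)C(Nc1cc(NS(=O)(=O)/C=C/c2c(OC)cc(OC)cc2OC)ccc1OC)c1ccc(F)cc1`: 2500 nM

In a functional assay on DU-145 cells (Homo sapiens) for cytotoxicity, read by trypan blue exclusion, with a stated time of 96 h (on this read-out lower numbers stand for stronger inhibition and higher numbers for weaker inhibition), compound 3 gives 2500 nM. It stands level with compound 1, and together they hold the highest number of the three, while compound 2 gives 350 nM.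

Compound 4 `COc1cc(OC)c(/C=C/S(=O)(=O)Nc2ccc(OC)c(NC(C(=O)O)c3ccc(F)cc3)c2)c(OC)c1` differs from compound 3 by hydrogen in place of methyl on an oxygen next to a carbonyl group. This is hydrogen in place of methyl on an oxygen next to a carbonyl group, so methoxycarbonyl becomes carboxy.

Going by the values given here, no measured step covers this change. The two nearest steps both concern the group that carries the methoxycarbonyl: a 7.1-fold lower number from compound 1 to compound 2 (0.85 log units; beyond the scatter), and a 7.1-fold higher number from compound 2 to compound 3 (0.85 log units; beyond the scatter). Both are modest, and they run in opposite directions. Neither shows what replacing this methyl with hydrogen does, so no step beyond the scatter is firmly expected, although one of similar size in either direction remains possible.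

The expected step in this assay is a 1.3-fold lower number from compound 3 to compound 4 (0.10 log units; within the scatter). The estimate for compound 4 is 2000 nM, with an expected range from 400 nM to 8000 nM.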

Compound 4, half-maximal inhibitory concentration: 75 nM
Beside the measured number, compound 4's estimate is 27-fold (1.43 log units) above it; the measured number lies below the stated range.
By their numbers in this assay, from the lowest: compound 4; then compound 2; then compounds 1 and 3 (each within the scatter of the next).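

In this assay, going by these compounds alone, the methoxycarbonyl on the shared side chain had stayed the same in compounds 2 and 3, so its change to carboxy is seen here for the first time, and at this position the change is large (a 33-fold lower number from compound 3 to compound 4 (1.52 log units; beyond the scatter)). Carboxy(4-fluorophenyl)methyl on the nitrogen also gives a lower number than (methoxycarbonyl)methyl (a 4.7-fold lower number from compound 2 to compound 4 (0.67 log units; beyond the scatter)), and (carboxy(4-fluorophenyl)methyl)amino a much lower one than nitro (a 33-fold lower number from compound 1 to compound 4 (1.52 log units; beyond the scatter)). The higher number seen with 4-fluorophenyl on the methyl ester therefore does not carry over to the carboxy compound.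

No measured evidence here accounts for these steps. The compounds shown leave open what carboxy does without the 4-fluorophenyl, and whether a primary amide or a longer chain ending in carboxy would give a similar number.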